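A few compounds are considered here, and "the series" means these few. Any claim that something is new, unique, unknown or untested is made for them only; others in the source may bear on it.

For the measured compounds named here, in a functional assay on MCF7 cells (Homo sapiens) for antiproliferative activity (a higher number here means a weaker inhibitor, a lower number a stronger inhibitor), compound 1 `CO[C@@H]1[C@@H](O)[C@@H](O)[C@H](Oc2ccc3c(c2C)OC(=O)C(n2cc(-c4ccccc4)nn2)C3)OC1(C)C` gives 64400 nM, the only readable number among the three compounds measured so far. Compound 2 `CC(=O)Oc1ccc2cc(-n3cc(-c4ccc(F)cc4F)nn3)c(=O)oc2c1C` reads > 100000 nM, which is a limit of the assay and not a number. Compound 3 `COc1ccc(-c2cn(-c3cc4ccc(OC(C)=O)c(C)c4oc3=O)nn2)cc1` reads > 100000 nM, which is also a limit.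

Compound 4 `CO[C@@H]1[C@@H](O)[C@@H](O)[C@H](Oc2ccc3c(c2C)OC(=O)C(n2cc(-c4ccc(N(C)C)cc4)nn2)C3)OC1(C)C` keeps the core of compound 1 and alters it in one place: dimethylamino in place of hydrogen on an aromatic carbon. This puts dimethylamino in place of hydrogen on an aromatic carbon, para to a large group, so that phenyl becomes 4-(dimethylamino)phenyl.

Going by the values given here, the only measured step that swaps one substituted phenyl for another is a step that the two limits leave unreadable from compound 2 to compound 3. It offers little guidance, since both of its ends sit at one ceiling: the limit of > 100000 nM in this assay, at which 2 of the 3 values shown sit. It also belongs to a core unlike that of compound 1. The data therefore give neither a size nor a direction for this change. With no readable step to draw on, the expectation rests on compound 1 at 64400 nM, and no shift beyond the usual scatter is predicted. The expected step is a 1.3-fold lower number from compound 1 to compound 4 (0.11 log units; within the scatter), which lies within that scatter. For compound 4 the estimated value is 50000 nM, with an expected range from 15000 nM to 100000 nM.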

Compound 4, half-maximal inhibitory concentration: > 100000 nM
Compound 4 was reported as a limit; the forecaster's own chance of this, stated with the estimate: 20%; middle value at least 2.0-fold (0.30 log units) away from the limit.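

For the compounds shown here, on the core of compound 1, this is the first change to the phenyl group that can be read at all: in this assay, the change is an at least 1.5-fold higher number from compound 1 to compound 4 (0.19 log units; that floor lies within the scatter). Compound 4 gives only a limit of the assay and not a number, so this step has a floor but no known size, and that floor does not separate the two compounds beyond the scatter. Still, the result shows that 4-(dimethylamino)phenyl in place of phenyl gives no readable number on this core, and it adds one more compound to those at the ceiling: the limit of > 100000 nM in this assay, at which 3 of the 4 values shown sit.

On these data alone, it remains open whether a primary amine, a hydroxyl or a carboxylic acid in place of that same hydrogen on the core of compound 1 would give a readable value, and so whether this position tolerates any group at all. The steps that end at limits on both sides cannot be read, so the compounds shown give no measured size for any swap of one substituted phenyl for another.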